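A few compounds are considered here, and "the series" means these few. Any claim that something is new, unique, unknown or untested is made for them only; others in the source may bear on it.

Compound 1 `Cc1ccc(C(/C=C/c2ccc(F)cc2)=N\Nc2nncc3ccccc23)cc1` — 3.4 nM
Compound 2 `Cc1cc(NS(=O)(=O)c2ccc(Nc3nncc4ccccc34)cc2)no1` — 13 nM
Compound 3 `C(=C/c1ccccc1)\C(=N\Nc1nncc2ccccc12)c1ccccc1` — 1.4 nM

In a functional assay on HeLa cells (Homo sapiens) for antiproliferative activity, read by sulforhodamine B assay, with a stated time of 72 h (on this read-out lower numbers stand for stronger inhibition and higher numbers for weaker inhibition), compound 2 stands at the highest of the three numbers shown. Compound 1 gives a lower number, and the gap between the two lies beyond the scatter; compound 3 gives the lowest number of the three, and its gap to compound 2 also lies beyond the scatter. Within the data shown here, compound 2 carries a sulfonamide that the other two do not, so the three structures are not linked by a single change, and no step between measured compounds is available for this set.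

Compound 4 `O=S(=O)(Nc1nccs1)c1ccc(Nc2nncc3ccccc23)cc1` keeps the whole of compound 2 apart from one place: 1,3-thiazol-2-yl in place of 5-methyl-1,2-oxazol-3-yl on a sulfonamide nitrogen. Among the measured compounds shown here, nothing among the measured compounds shows what such an exchange does in this assay, so the expectation rests on the value of compound 2 alone, with a range wide enough to allow for a change in either direction. The step of a 1.2-fold higher number from compound 2 to compound 4 (0.06 log units; within the scatter) is therefore expected to be small, and not to reach beyond the scatter. On that basis compound 4 is estimated to give 15 nM in this assay, within a range from 5 nM to 45 nM.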

Compound 4, half-maximal inhibitory concentration: 15 nM
Beside the measured number, compound 4's estimate shows no gap at the digits printed; measured number inside the range.
By their numbers in this assay, from the lowest: compound 3; then compound 1; then compounds 2 and 4 (each within the scatter of the next).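

In this assay, among these compounds, putting 1,3-thiazol-2-yl in place of 5-methyl-1,2-oxazol-3-yl on a sulfonamide nitrogen gives a 1.2-fold higher number from compound 2 to compound 4 (0.06 log units; within the scatter) and provides the first reading at this position, which the earlier compounds, linked by no single change, could not give. Among the compounds shown here, although the two groups differ in their heavy atoms, one bringing sulfur and the other oxygen, and only the one that leaves carries a methyl, this assay does not separate them, so at this position these two five-membered aromatic rings with 2 hetero atoms can be exchanged with no change beyond the scatter. No evidence on any property of either group accompanies this result, and the numbers alone offer no account of it.

From the compounds shown here alone, the two compounds cover only these two rings, so it remains open how the read-out would respond to a six-membered ring such as pyridin-2-yl, to a small open-chain group such as methyl or acetyl on the same nitrogen, or to a carboxylic acid or an amine carried on the ring. Compound 1 and compound 3 differ from compound 2 and compound 4 in more than one place, so the steps that would link them cannot be read.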